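The source may hold more compounds than are shown below. What is called first, only, known or untested is meant among the compounds shown, and "the series" means these compounds.

Measured compounds in a functional assay on MCF7 cells (Homo sapiens) for cytotoxicity, read by MTT assay, with a stated time of 96 h; on this read-out higher numbers stand for weaker inhibition and lower numbers for stronger inhibition:
compound 1 `COc1cc(C(=O)c2cn(-c3cccc(N)c3)cc2-c2ccccc2F)cc(OC)c1OC`, 17 nM
compound 2 `COc1cc(C(=O)c2cn(-c3cccc(N)c3)cc2-c2ccccc2Cl)cc(OC)c1OC`, 40 nM
compound 3 `COc1cc(C(=O)c2cn(-c3ccc(C)cc3)cc2-c2ccccc2F)cc(OC)c1OC`, 44 nM

Compound 4 `COc1cc(C(=O)c2cn(-c3ccc(C)cc3)cc2-c2ccccc2Cl)cc(OC)c1OC` has not been measured in this assay. It arises from compound 3 by chloro in place of fluoro on an aromatic carbon. The same change, (chloro in place of fluoro on an aromatic carbon), has been measured once and gave a 2.4-fold higher number from compound 1 to compound 2 (0.37 log units; beyond the scatter). The two cores differ by 4-methylphenyl in place of 3-aminophenyl on an aromatic nitrogen; the place of the halogen change is described in the same words for both pairs, so the change is taken as the same. Compound 2 and compound 3 lie within the scatter of each other. Within the data shown here, the step from compound 3 to compound 4 in this assay is expected to resemble the earlier one, a 2.4-fold higher number from compound 3 to compound 4 (0.38 log units; beyond the scatter), because a 2.4-fold higher number from compound 1 to compound 2 (0.37 log units; beyond the scatter) is the only measurement of this change so far. Compound 4 is therefore estimated at about 105 nM, with a range of 50 nM to 220 nM.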

Compound 4, half-maximal inhibitory concentration: 180 nM
Compound 4: the middle estimate sits 1.7-fold (0.23 log units) below what was measured; low and high end bracket the measured number.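

In this assay, chloro in place of fluoro on an aromatic carbon gives a 4.1-fold higher number from compound 3 to compound 4 (0.61 log units; beyond the scatter), and the halogen step holds its direction on both cores: the same change on two cores in this assay, a 2.4-fold higher number (0.37 log units; beyond the scatter) from compound 1 to compound 2 and a 4.1-fold higher number (0.61 log units; beyond the scatter) from compound 3 to compound 4, 1.7-fold (0.24 log units) apart, within the scatter of two such steps. Likewise, 4-methylphenyl in place of 3-aminophenyl on an aromatic nitrogen gives a 4.5-fold higher number from compound 2 to compound 4 (0.65 log units; beyond the scatter), and this step also holds its direction with either halogen: the same change on two cores in this assay, a 2.6-fold higher number (0.41 log units; beyond the scatter) from compound 1 to compound 3 and a 4.5-fold higher number (0.65 log units; beyond the scatter) from compound 2 to compound 4, 1.7-fold (0.24 log units) apart, within the scatter of two such steps. With one pair per core, this shows that both changes carried over between these two cores, but it does not show that they would carry over to other cores or why they act as they do.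

Open, from the compounds shown here alone, is how bromo, methyl or methoxy would compare with fluoro and chloro at this place. Also open, going by these compounds, is how a hydroxyl or a carboxylic acid would compare with the amine on the phenyl group.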